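Ethynyl for isopropyl at the cytotoxicity ceiling

This account rests on a few compounds, and the source may have more. Where it says the series, first, only, none or still open, it means among the compounds named here.

Of the compounds shown here, three built on one shared core have been measured in an ADME assay on HepG2 cells (Homo sapiens) for cytotoxicity; a higher number here means that more compound is needed for the effect, a lower number that less compound is needed. Compound 1, `Cc1ccc(S(=O)(=O)N[C@@H](CC(=O)NC(C)(C)C)C(=O)NCCNC(=O)c2cc(Cl)ccn2)cc1`, gives in this assay only the limit > 11000 nM. Compound 2, `Cc1ccc(S(=O)(=O)N[C@@H](CC(=O)NC(C)(C)C)C(=O)NCCNC(=O)c2cccc(C(C)C)c2)cc1`, likewise reaches only the limit > 11000 nM in this assay. Compound 3, `Cc1ccc(S(=O)(=O)N[C@@H](CC(=O)NC(C)(C)C)C(=O)NCCNC(=O)c2cc(C)ccc2F)cc1`, returns the limit > 11000 nM in this assay as well. The three steps between them, a step that the two limits leave unreadable from compound 1 to compound 2, a step that the two limits leave unreadable from compound 1 to compound 3 and a step that the two limits leave unreadable from compound 2 to compound 3, stay unreadable because of the limit of > 11000 nM in this assay, at which 3 of the 3 values shown sit. Compound 2 therefore stands where every measured compound stands: at the limit, with no number of its own.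

Compound 4, `C#Cc1cccc(C(=O)NCCNC(=O)[C@H](CC(=O)NC(C)(C)C)NS(=O)(=O)c2ccc(C)cc2)c1`, has not yet been measured in this assay. It differs from compound 2 in one place: ethynyl in place of isopropyl on an aromatic carbon. Within the data shown here, none of the measured steps touches this position, and none of them has a readable size, so the only guidance is that three varied groups on the same carbonyl carbon all left the limit untouched. The step from compound 2 to compound 4 is expected to be a step that the limit leaves unreadable from compound 2 to compound 4, meaning nothing beyond the scatter. Compound 4 is accordingly expected to give about 15000 nM in this assay, with an estimated range from 7000 nM to 40000 nM, most likely reported again as a limit.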

Compound 4, half-maximal effective concentration: > 11000 nM
Compound 4 gave a limit, no number; the forecaster's own chance of this, stated with the estimate: 85%; the middle value does not contradict the limit.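

The steps linking compound 4 to compound 1, compound 2 and compound 3 cannot be read, because each of the four compounds gives a limit rather than a number: the limit of > 11000 nM in this assay, at which 4 of the 4 values shown sit.

The compounds shown leave open how much of any of them is needed for the effect in this assay, and whether ethynyl and isopropyl differ there at all.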